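This account rests on a few compounds, and the source may have more. Where it says the series, first, only, none or still open, it means among the compounds named here.

Working notes on the series. Compound 1 `Fc1ccc(-c2cc3ccccc3[nH]2)cc1` gives 21.8% in an assay on isolated protein for inhibition of Aromatase (Homo sapiens), read by fluorescence, using NADPH, with a stated time of 30 min, tested at 50 uM; a higher number here means more inhibition at the concentration tested (going by the name of the read-out), a lower number less inhibition. Compound 2 `Cc1ccc2cc(-c3ccccc3)[nH]c2c1` gives 32.4% in this assay. Compound 3 `CCCCCc1ccc(-c2cc3ccccc3[nH]2)cc1` gives 0% in this assay, the lowest of the three numbers, with compound 1 nearest and compound 2 furthest, both gaps beyond the scatter. Within the data shown here, the one single-point step measured so far is a number 21.8 percentage points lower from compound 1 to compound 3 (beyond the scatter). Compound 4 `Brc1ccc(-c2cc3ccccc3[nH]2)cc1` differs from compound 3 as follows: bromo in place of pentyl on an aromatic carbon. Among the measured compounds shown here, only that step bears on the change, since bromo resembles fluoro more than pentyl. Read in reverse, it suggests the number of compound 4 should move back up, an expected step of a number 25 percentage points higher from compound 3 to compound 4 (beyond the scatter). Compound 4 is therefore estimated at 25% in this assay, with a range from 5% to 45%.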

Compound 4, a percentage reported as inhibition, at one concentration (the size of the read-out at that concentration, not a potency): 4.8%
Estimate against measurement, compound 4: 20.2 percentage points above, and the stated range ends above it.
By their numbers in this assay, from the lowest: compounds 3 and 4 (each within the scatter of the next); then compound 1; then compound 2.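

In this assay bromo in place of pentyl gives a number 4.8 percentage points higher from compound 3 to compound 4 (within the scatter) and so losing the pentyl chain does not by itself bring back the number of compound 1. Bromo in place of fluoro at the same aromatic carbon gives a number 17 percentage points lower from compound 1 to compound 4 (beyond the scatter) and so these two halogens do not read alike at this position. Nothing on hand explains that difference. Open, from the compounds shown here alone, is whether chloro at this position would read nearer compound 1 or compound 4. Also open, going by these compounds, is how an amine or a carboxylic acid would read there.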